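Methyl in Place of Chloro on the Ketone Aryl Ring

This account rests on a few compounds, and the source may have more. Where it says the series, first, only, none or still open, it means among the compounds named here.

Three compounds have been measured in a functional assay on A549 cells (Homo sapiens) for antiproliferative activity, read by MTT assay, with a stated time of 24 h; a lower number here means a stronger inhibitor, a higher number a weaker inhibitor:

Compound 1, `COc1ccc(-c2cc(/C=C/C(=O)c3cc(OC)c(OC)c(OC)c3)nc3cc(-c4ccccc4)nn23)cc1OC`: 7200 nM
Compound 2, `COc1ccc(-c2cc(/C=C/C(=O)c3ccc(Cl)cc3)nc3cc(-c4ccccc4)nn23)cc1OC`: 15400 nM
Compound 3, `COc1ccc(/C=C/C(=O)c2cc(-c3cc(OC)c(OC)c(OC)c3)n3nc(-c4ccccc4)cc3n2)cc1OC`: 20500 nM

Compound 2 stands second highest of the three numbers. Its nearest neighbour is compound 3, whose 20500 nM lies within the scatter of that of compound 2, so no order between the two can be claimed. Within the data shown here, compound 1 gives the lowest number of the set, and the step of a 2.1-fold higher number from compound 1 to compound 2 (0.33 log units; beyond the scatter) is the only one-place change measured so far; it comes from 4-chlorophenyl in place of 3,4,5-trimethoxyphenyl on a carbonyl carbon.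

Compound 4, `COc1ccc(-c2cc(/C=C/C(=O)c3ccc(C)cc3)nc3cc(-c4ccccc4)nn23)cc1OC`, is the next compound to be measured. It differs from compound 2 by methyl in place of chloro on an aromatic carbon. The group that leaves and the group that enters each count one heavy atom, neither carries a donor or acceptor, and the place, on an aromatic carbon of a six-membered aromatic ring of carbon only, para to a large group, is unchanged. Among the measured compounds shown here, no measured step tests this exchange directly; the step from compound 1 to compound 2 changes a whole ring rather than a single substituent, so it gives only a loose bound. The expectation is therefore a step of a 1.1-fold higher number from compound 2 to compound 4 (0.04 log units; within the scatter) that stays within the scatter. Compound 4 is accordingly estimated at 17000 nM, with a range from 8000 nM to 36000 nM.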

Compound 4, half-maximal inhibitory concentration: 17200 nM
Compound 4: the middle estimate sits 1.0-fold (0.01 log units) below what was measured; measured number inside the range.
By their numbers in this assay, from the lowest: compound 1; then compounds 2, 4 and 3 (each within the scatter of the next).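

In this assay, methyl in place of chloro on an aromatic carbon gives a 1.1-fold higher number from compound 2 to compound 4 (0.05 log units; within the scatter), so at this place on the ketone aryl ring the two groups cannot be told apart. The earlier compounds shown here offered only a whole-ring change, whereas a second whole-ring change, this time to 4-methylphenyl, now gives a 2.4-fold higher number from compound 1 to compound 4 (0.38 log units; beyond the scatter), a modest step beyond the scatter, just as the change to 4-chlorophenyl gives a 2.1-fold higher number from compound 1 to compound 2 (0.33 log units; beyond the scatter). The gap to compound 1 therefore does not rest on chloro alone and is seen with both of these groups, though no measurement here explains why the chloro and methyl compounds read alike or why either stands apart from compound 1.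

The compounds shown leave open whether any group at this place would give a step beyond the scatter, such as an amine, a carboxylic acid or a longer chain like n-butyl. They also leave open whether a single methoxy at this place, rather than the full 3,4,5-trimethoxyphenyl ring, would read closer to compound 1 or to compound 4.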